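This account rests on a few compounds, and the source may have more. Where it says the series, first, only, none or still open, it means among the compounds named here.

Of the compounds shown here, three have been measured in an ADME assay on MT2 cells (Homo sapiens) for cytotoxicity, read by XTT assay, with a stated time of 4 days; a higher number here means that more compound is tolerated, a lower number that less compound is tolerated.

Compound 1, `Cc1cc(/C=C2\SC(=S)N(Cc3ccc(C(F)(F)F)cc3)C2=O)c(C)n1-c1ccc(O)c(C(=O)O)c1`, gives 45900 nM.
Compound 2, `Cc1cc(/C=C2\SC(=S)N(Cc3ccc(Br)cc3)C2=O)c(C)n1-c1ccc(O)c(C(=O)O)c1`, gives 94400 nM.
Compound 3, `Cc1cc(/C=C2\SC(=S)N(Cc3cccc(C(F)(F)F)c3)C2=O)c(C)n1-c1ccc(O)c(C(=O)O)c1`, gives 26300 nM.

All three share one core and differ in a single group. Compound 1 and compound 2 differ by bromo in place of trifluoromethyl on an aromatic carbon, and this change brought a 2.1-fold higher number from compound 1 to compound 2 (0.31 log units; beyond the scatter). Compound 1 and compound 3 are built from the same atoms joined differently: 3-(trifluoromethyl)phenyl in place of 4-(trifluoromethyl)phenyl on a saturated chain carbon bound to an amide-type nitrogen in a ring. Here a 1.7-fold lower number from compound 1 to compound 3 (0.24 log units; within the scatter), so these two cannot be told apart. Between compound 2 and compound 3 there is a 3.6-fold lower number from compound 2 to compound 3 (0.56 log units; beyond the scatter).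

Compound 4, `Cc1cc(/C=C2\SC(=S)N(Cc3cccc(Br)c3)C2=O)c(C)n1-c1ccc(O)c(C(=O)O)c1`, has not yet been measured in this assay. It differs from compound 3 by bromo in place of trifluoromethyl on an aromatic carbon. Among the measured compounds shown here, this is the same kind of change as the one from compound 1 to compound 2, but not the same: there the bromo entered para to a large group, here it enters meta to a large group. For the measured compounds named here, only one earlier example of this change exists, so the expectation rests on a single step. Expected in this assay is a 1.9-fold higher number from compound 3 to compound 4 (0.28 log units; within the scatter) because a 2.1-fold higher number from compound 1 to compound 2 (0.31 log units; beyond the scatter) is the one earlier measurement of this change, and the different placement adds uncertainty. For compound 4 the estimated value is 50000 nM, with a likely range from 20000 nM to 125000 nM.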

Compound 4, half-maximal cytotoxic concentration: 48200 nM
Compound 4: the middle estimate sits 1.0-fold (0.02 log units) above what was measured; low and high end bracket the measured number.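

In this assay, putting bromo in place of trifluoromethyl gave closely matching steps whether the group sat on the 4-substituted or the 3-substituted benzyl group: the same change on two cores in this assay, a 2.1-fold higher number (0.31 log units; beyond the scatter) from compound 1 to compound 2 and a 1.8-fold higher number (0.26 log units; within the scatter) from compound 3 to compound 4, 1.1-fold (0.05 log units) apart, within the scatter of two such steps

Among the compounds shown here, this agreement supports carrying the change between these two closely related compound pairs, but it rests on only two examples, and the newer step, a 1.8-fold higher number from compound 3 to compound 4 (0.26 log units; within the scatter), is too small on its own to separate its two compounds. It also shows nothing about a core that differs elsewhere, and the other two steps add no clear difference: a 2.0-fold lower number from compound 2 to compound 4 (0.29 log units; within the scatter) for moving the bromo from 4-bromophenyl to 3-bromophenyl, and a 1.1-fold higher number from compound 1 to compound 4 (0.02 log units; within the scatter) for 3-bromophenyl in place of 4-(trifluoromethyl)phenyl, leave compound 4 indistinguishable from both compound 1 and compound 2.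

The compounds shown carry only bromo or trifluoromethyl on the benzyl group, so it remains open how a chloro, a methoxy or a nitrile at that place would compare. From the compounds shown here alone, every compound also keeps the same carboxylic acid and hydroxyl on the other aromatic ring, so the effect of replacing either group, for example the acid with an ester, also remains open.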